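The compounds below may be only part of what the source reports. "The series", "measured", "known", "first", "only" and "open" are said of these compounds alone.

Working notes on the series in an assay for binding affinity to metabotropic glutamate receptor 5 (Rattus norvegicus); on this read-out lower numbers stand for stronger inhibition and higher numbers for weaker inhibition.

Compound 2 `Cc1ncccc1-c1cc(F)cc(-n2nnc(-c3ccccn3)n2)c1` sits at 45 nM. Among the compounds with values here, compound 1 `Cc1cccnc1-c1cc(F)cc(-n2nnc(-c3ccccn3)n2)c1`, the only other measured member, gives 24 nM in this assay, and the one recorded step, a 1.9-fold higher number from compound 1 to compound 2 (0.27 log units; within the scatter), keeps the pair inside the scatter, so neither compound can be called stronger than the other on these numbers.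

Compound 3 `Nc1cccnc1-c1cc(F)cc(-n2nnc(-c3ccccn3)n2)c1` is the next member. Its change against compound 2 is 3-aminopyridin-2-yl in place of 2-methylpyridin-3-yl on an aromatic carbon. Within the data shown here, no measured step covers an amino group on that ring or this exact exchange; the only step known here, a 1.9-fold higher number from compound 1 to compound 2 (0.27 log units; within the scatter), swaps the attachment point of a methyl-bearing pyridyl and stays within the scatter. The series has so far been tolerant at this position, and on that basis no step beyond the scatter is expected from compound 2 to compound 3 in this assay, no change at the digits printed from compound 2 to compound 3 (within the scatter). Compound 3 is therefore estimated at 45 nM, with a range of 12 nM to 160 nM.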

Compound 3, inhibition constant: 31 nM
Compound 3: middle estimate off by 1.5-fold (0.16 log units), on the high side; measured number inside the range.
By their numbers in this assay, from the lowest: compounds 1, 3 and 2 (each within the scatter of the next).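

In this assay the exchange of 2-methylpyridin-3-yl for 3-aminopyridin-2-yl gives a 1.5-fold lower number from compound 2 to compound 3 (0.16 log units; within the scatter) and amino in place of methyl gives a 1.3-fold higher number from compound 1 to compound 3 (0.11 log units; within the scatter) on the same attachment. The earlier pair held only methyl-bearing pyridyl groups, whereas these steps show that, across these three compounds, a group with 1 hydrogen-bond donor and groups with 0 hydrogen-bond donors stand at this place without a step beyond the scatter. No evidence is at hand that bears on this result.

The compounds shown leave open whether the tolerance extends to a hydroxyl, a dimethylamino group or a carboxylic acid in place of the amino group. Also open, going by these compounds, is what an unsubstituted pyridyl or a plain phenyl would give at this place.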